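The source may report more compounds than this note shows. Statements on the series, on what has been measured and on what is new or still open speak of the compounds shown alone.

Measured so far:
compound 1 `CC#CCN(C)Cc1cc2cc(O)ccc2n1C` gives 5.7 nM
compound 2 `C#CCN(C)Cc1cc2ccccc2n1C` gives 0.3 nM

In an assay on isolated protein for inhibition of Amine oxidase [flavin-containing] A (Rattus norvegicus) (on this read-out lower numbers stand for stronger inhibition and higher numbers for weaker inhibition), compound 2 stands at the lowest of the two numbers shown; the only neighbour is compound 1, whose value lies beyond the scatter above it, though compound 1 differs from compound 2 in more than one place, so no single step can be read from that pair. Compound 3 `CC#CCN(C)Cc1cc2ccccc2n1C` carries methyl in place of hydrogen on a triple-bonded carbon, that is, methyl in place of hydrogen on a triple-bonded carbon. A step from compound 2 to compound 3 toward weaker inhibition is expected, of the size a 10-fold higher number from compound 2 to compound 3 (1.00 log units; beyond the scatter). Compound 3 is estimated at 3 nM, between 0.6 nM and 15 nM.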

Compound 3, inhibition constant: 4.3 nM
Compound 3: middle estimate off by 1.4-fold (0.16 log units), on the low side; the range from low to high includes it.
By their numbers in this assay, from the lowest: compound 2; then compounds 3 and 1 (each within the scatter of the next).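

The triple-bonded carbon proves to be a responsive position in this assay: methyl in place of hydrogen there gives a large step toward weaker inhibition (a 14-fold higher number from compound 2 to compound 3 (1.16 log units; beyond the scatter)). Among these compounds, the first single-change reading at the aromatic carbon shows no such effect for hydrogen in place of hydroxy (a 1.3-fold lower number from compound 1 to compound 3 (0.12 log units; within the scatter)). No evidence here explains either step.
Still open, from the compounds shown here alone, is how a longer chain, such as ethyl, or a phenyl group on the triple-bonded carbon would read. Also open, going by these compounds, is whether methoxy or fluorine on the aromatic carbon would read like hydroxy.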